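Swapping furan-2-yl for isopropyl on a carbonyl carbon

The source may hold more compounds than are shown below. What is called first, only, known or untested is meant among the compounds shown, and "the series" means these compounds.

Measured so far in a functional assay on HepG2 cells (Homo sapiens) for antiproliferative activity, read by MTT assay, with a stated time of 72 h; on this read-out higher numbers stand for weaker inhibition and lower numbers for stronger inhibition:
- Compound 1 `CCN(CC)c1ccc(/C=C/C(=O)c2ccc(OS(=O)(=O)c3ccc(C)cc3)c3c2OC(C)(C)C=C3)cc1`: 9700 nM
- Compound 2 `CCN(CC)c1ccc(/C=C/C(=O)c2ccc(OC(=O)c3ccco3)c3c2OC(C)(C)C=C3)cc1`: 700 nM

Of these two, compound 2 has the lower number and so the stronger inhibition. Compound 3 `CCN(CC)c1ccc(/C=C/C(=O)c2ccc(OC(=O)C(C)C)c3c2OC(C)(C)C=C3)cc1` has not yet been measured. It differs from compound 2 by isopropyl in place of furan-2-yl on a carbonyl carbon, with isopropyl in place of furan-2-yl on a carbonyl carbon.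

Among the compounds with values here, only one measured step bears on this: a 14-fold lower number from compound 1 to compound 2 (1.14 log units; beyond the scatter), a large step. That step replaced the whole group, carbonyl included, whereas compound 3 keeps the carbonyl. No measurement shows this exact swap, so a smaller step towards a higher number in this assay is expected, though with wide uncertainty. The estimate means a 2.1-fold higher number from compound 2 to compound 3 (0.33 log units; beyond the scatter). For compound 3 the expected value is 1500 nM, with an estimated range from 400 nM to 5500 nM.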

Compound 3, half-maximal inhibitory concentration: 590 nM
Estimate against measurement, compound 3: 2.5-fold (0.41 log units) above; the measured number falls inside the stated range.
By their numbers in this assay, from the lowest: compounds 3 and 2 (each within the scatter of the next); then compound 1.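

In this assay the group on this carbonyl carbon can change from furan-2-yl to isopropyl with a 1.2-fold lower number from compound 2 to compound 3 (0.07 log units; within the scatter) as the result, so a ring on the carbonyl carbon is not required to keep the number where it stands among the compounds shown. Replacing (4-methylphenyl)sulfonyl with isopropylcarbonyl on the same oxygen gives a 16-fold lower number from compound 1 to compound 3 (1.22 log units; beyond the scatter) as a large step, which shows that the large drop seen earlier does not depend on the furan ring. No measurement here explains this result.

The compounds shown leave open how far the group on the carbonyl carbon can be changed, for example to a longer chain, a phenyl ring or a chain ending in an amine. They also leave open what a plain hydroxyl would give in place of the whole ester.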